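The source may report more compounds than this note shows. Statements on the series, on what has been measured and on what is new or still open speak of the compounds shown alone.

Compound 1 `COc1nc(N)nc2c1c(-c1ccccc1)cn2[C@@H]1O[C@H](CO)[C@@H](O)[C@H]1O` gives > 20000 nM in a functional assay on K562 cells (Homo sapiens), read by MTT assay, with a stated time of 72 h; a higher number here means a weaker inhibitor, a lower number a stronger inhibitor; this value is a limit of the assay, not a number.
Compound 2 `COc1nc(N)nc2c1c(-c1ccsc1)cn2[C@@H]1O[C@H](CO)[C@@H](O)[C@H]1O` gives > 20000 nM in this assay; this too is a limit.
Compound 3 `Nc1nc2c(c(-c3ccccc3)cn2[C@@H]2O[C@H](CO)[C@@H](O)[C@H]2O)c(=O)[nH]1` gives > 20000 nM in this assay; again only a limit.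

Compound 4 `Nc1nc2c(c(-c3ccsc3)cn2[C@@H]2O[C@H](CO)[C@@H](O)[C@H]2O)c(=O)[nH]1` has not yet been measured. From compound 3 to compound 4 the change is thiophen-3-yl in place of phenyl on an aromatic carbon. The same kind of change runs from compound 1 to compound 2, (thiophen-3-yl in place of phenyl on an aromatic carbon); the two places read alike except that in the earlier pair the group on the ring atom is named in full rather than only counted. The difference between the core of compound 1 and the core of compound 3 is not broken down here. The step that the two limits leave unreadable from compound 1 to compound 2 cannot be sized because of the limit of > 20000 nM in this assay, at which 3 of the 3 values shown sit. With no readable step to lean on, compound 4 is expected to stay at the same limit, so the expected step that the limit leaves unreadable from compound 3 to compound 4 is small. Compound 4 is estimated at 30000 nM, expected to lie between 10000 nM and 100000 nM.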

Compound 4, half-maximal inhibitory concentration: > 20000 nM
Compound 4: a limit, no number; the forecaster's own chance of this, stated with the estimate: 85%; the middle value lies beyond the limit too.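

No size can be read for the change from compound 3 to compound 4, because both values are limits, not numbers: the limit of > 20000 nM in this assay, at which 4 of the 4 values shown sit.

The compounds shown leave open whether thiophen-3-yl in place of phenyl changes anything in this assay on either core.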